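Swapping one aromatic group on a high-exposure compound

The source may report more compounds than this note shows. Statements on the series, on what has been measured and on what is new or still open speak of the compounds shown alone.

Among the three compounds measured in an ADME assay on the whole organism (Mus musculus, strain Swiss Webster) for pharmacokinetics, read by LC-MS, at a dose of 50 mg/kg by the oral route (a lower number here means less compound in the circulation, a higher number more compound in the circulation at the dose given), compound 3 (`O=C(Nc1ccc(F)c(-c2nc3ncc(-c4cccnc4F)cc3[nH]2)c1)N1CCCC1`) stands highest at 30900 ng.h/mL ahead of compound 1 (`O=C(Nc1ccc(F)c(-c2nc3ncc(-c4ccc(F)c(F)c4)cc3[nH]2)c1)N1CCCC1`) at 12000 ng.h/mL and compound 2 (`O=C(Nc1ccc(F)c(-c2nc3ncc(-c4cncc(F)c4)cc3[nH]2)c1)N1CCCC1`) at 1560 ng.h/mL on the same scale. Compound 4 (`O=C(Nc1ccc(F)c(-c2nc3ncc(-c4ccc(O)cc4)cc3[nH]2)c1)N1CCCC1`) differs from compound 3 in one place (4-hydroxyphenyl in place of 2-fluoropyridin-3-yl on an aromatic carbon) where 4-hydroxyphenyl replaces 2-fluoropyridin-3-yl. Earlier exchanges at this place gave a 7.7-fold lower number from compound 1 to compound 2 (0.89 log units; beyond the scatter) then a 2.6-fold higher number from compound 1 to compound 3 (0.41 log units; beyond the scatter) and a 20-fold higher number from compound 2 to compound 3 (1.30 log units; beyond the scatter) so the number moved in both directions. None of these compounds carries a hydroxyl group, so the guide is indirect. Compound 3 sits at the top with 30900 ng.h/mL so a fall is the likelier outcome. The expected step is a 7.7-fold lower number from compound 3 to compound 4 (0.89 log units; beyond the scatter) as a rough guide. The estimated value for compound 4 is 4000 ng.h/mL with 700 ng.h/mL to 20000 ng.h/mL as its expected range.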

Compound 4, area under the concentration-time curve: 137 ng.h/mL
The estimate for compound 4 lay 29-fold (1.47 log units) above the measured number, and the stated range ends above it.
By their numbers in this assay, from the lowest: compound 4; then compound 2; then compound 1; then compound 3.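

The 4-hydroxyphenyl group sets a new low in this assay (a 230-fold lower number from compound 3 to compound 4 (2.35 log units; beyond the scatter)), and it also falls well short of the other two compounds (an 88-fold lower number from compound 1 to compound 4 (1.94 log units; beyond the scatter); an 11-fold lower number from compound 2 to compound 4 (1.06 log units; beyond the scatter)), so this position can lower the number much further than the three fluorinated rings showed. Going by these compounds alone, it is the only group here with a hydrogen-bond donor and the only one without fluorine. Nothing available explains the fall.

The compounds shown leave open which of those two differences goes with the drop. A 4-methoxyphenyl or 4-fluorophenyl group at this place would help separate them.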